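This account rests on a few compounds, and the source may have more. Where it says the series, first, only, none or still open, it means among the compounds named here.

Of the compounds shown here, three sharing one core have been measured in a functional assay on MDA-MB-231 cells (Homo sapiens) for cytotoxicity, read by MTT assay, with a stated time of 48 h; a lower number here means a stronger inhibitor, a higher number a weaker inhibitor. Compound 1 `O=C(/C=C\Nc1ccc(F)cc1)c1nc(-c2ccc(F)cc2)n2ccccc12` gives 25100 nM. Compound 2 `COc1ccc(-c2nc(C(=O)/C=C\Nc3ccc4[nH]ccc4c3)c3ccccn23)cc1` gives 28700 nM. For compound 3 `COc1ccc(N/C=C\C(=O)c2nc(-c3ccc(C(F)(F)F)cc3)n3ccccc23)cc1OC` this assay returns only a limit, > 30000 nM, which is the limit of > 30000 nM in this assay, at which 1 of the 3 values shown sits, so compound 3 cannot be placed more precisely than that. Compound 4 `O=C(/C=C\Nc1ccc2cc[nH]c2c1)c1nc(-c2ccc(C(F)(F)F)cc2)n2ccccc12` is not yet measured. It differs from compound 3 in one place: 1H-indol-6-yl in place of 3,4-dimethoxyphenyl on an amine nitrogen. Among the measured compounds shown here, no pair of measured compounds differing in a single place is available, so the size of this step is not anchored by data. Compound 2 also carries an indolyl group on the amine nitrogen and gives 28700 nM. Compound 4 is therefore expected to stay weak, with the step of a number no higher from compound 3 to compound 4 (the limit leaves the size open) expected to fall within the scatter. Compound 4 is estimated at 30000 nM, between 15000 nM and 60000 nM.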

Compound 4, half-maximal inhibitory concentration: > 30000 nM
Compound 4: a limit, no number; the forecaster's own chance of this, stated with the estimate: 50%; the middle value sits exactly at the limit.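

Compound 3 and compound 4 both return only a limit, so no step between them can be read: the limit of > 30000 nM in this assay, at which 2 of the 4 values shown sit.

The compounds shown leave open whether 1H-indol-6-yl or 3,4-dimethoxyphenyl on the amine nitrogen gives the stronger inhibitor.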